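The source may report more compounds than this note shows. Statements on the series, on what has been measured and on what is new or still open speak of the compounds shown alone.

Compounds measured in a functional assay for agonist activity at G protein-coupled receptor 88 (Homo sapiens), read by HTRF and cAMP accumulation; a higher number here means that more compound is needed for the effect, a lower number that less compound is needed:
- compound 1 `CC(C)C[C@H](N)CN(C(=O)[C@@H]1C[C@H]1c1ccccc1)c1ccc(-c2ccccc2)cc1` gives 880 nM
- compound 2 `CN[C@@H](CC(C)C)CN(C(=O)[C@@H]1C[C@H]1c1ccccc1)c1ccc(-c2ccccc2)cc1` gives 2 nM
- compound 3 `O=C([C@@H]1C[C@H]1c1ccccc1)N(CCNCC1CCCCC1)c1ccc(-c2ccccc2)cc1` gives 6.6 nM

Compound 1 has the highest number of the three. Its nearest neighbour is compound 3, reached by a 130-fold lower number from compound 1 to compound 3 (2.12 log units; beyond the scatter); the furthest is compound 2, reached by a 440-fold lower number from compound 1 to compound 2 (2.64 log units; beyond the scatter). Between the two lower values the gap is a 3.3-fold higher number from compound 2 to compound 3 (0.52 log units; beyond the scatter).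

Compound 4 `CC(C)C[C@H](N)CN(C(=O)[C@@H]1C[C@H]1c1ccccc1)c1ccc(-c2ccc(Cl)cc2)cc1` differs from compound 1 in one place: chloro in place of hydrogen on an aromatic carbon. Every measured step in this series alters the amine-bearing chain, while the substituted aromatic ring of compound 4 is left untouched in compounds 1, 2 and 3, so none of those steps bears on this change and the series gives no guide to its size or direction. Within the data shown here, with no comparable precedent, the expectation for compound 4 is a step of no change at the digits printed from compound 1 to compound 4 (within the scatter), that is, nothing beyond the scatter, though the range must be kept wide. Compound 4 is therefore estimated at 880 nM in this assay, with a range from 250 nM to 3000 nM.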

Compound 4, half-maximal effective concentration: 640 nM
For compound 4 the middle estimate is 1.4-fold (0.14 log units) above the measured one; measured number inside the range.
By their numbers in this assay, from the lowest: compound 2; then compound 3; then compounds 4 and 1 (each within the scatter of the next).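

In this assay, going from phenyl to 4-chlorophenyl gives a 1.4-fold lower number from compound 1 to compound 4 (0.14 log units; within the scatter), so chloro on this aromatic carbon, para to a large group, leaves the number within the scatter. Among these compounds, this is the only measured change outside the amine-bearing chain, and it stands against a 440-fold lower number from compound 1 to compound 2 (2.64 log units; beyond the scatter), the large step from methyl on the amine nitrogen. No supporting measurement bears on why chloro is accommodated here.

Going by these compounds, it remains open whether the same chloro change would also stay within the scatter on compound 2, where the number is already much lower, or on compound 3. Also open, on these data alone, is how a larger or different group at this place would read, such as methoxy, trifluoromethyl, a carboxylic acid or an amine.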